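Replacing an aryl amide with a benzyl amide

A few compounds are considered here, and "the series" means these few. Any claim that something is new, unique, unknown or untested is made for them only; others in the source may bear on it.

Within the data shown here, in a functional assay on MGC-803 cells (Homo sapiens) for inhibition, read by MTT assay, with a stated time of 72 h (on this read-out lower numbers stand for stronger inhibition and higher numbers for weaker inhibition), compound 2 `O=C(Nc1ccc(F)c(Br)c1)C1CCN(C/C=C/c2ccccc2)CC1` gives 9270 nM and stands lowest of the two measured numbers, while compound 1 `COc1ccccc1NC(=O)C1CCN(C/C=C/c2ccccc2)CC1` gives 71200 nM as the only other number. Compound 3 `O=C(NCc1ccccc1)C1CCN(C/C=C/c2ccccc2)CC1` brings the change benzyl in place of 3-bromo-4-fluorophenyl on an amide-type nitrogen and so puts benzyl in place of 3-bromo-4-fluorophenyl on an amide-type nitrogen. Among the measured compounds shown here, the one measured step at this nitrogen was modest but beyond the scatter, namely a 7.7-fold lower number from compound 1 to compound 2 (0.89 log units; beyond the scatter) on gaining the 3-bromo-4-fluorophenyl group. With that group gone, the expected move in this assay is upward, an estimated 3.0-fold higher number from compound 2 to compound 3 (0.48 log units; beyond the scatter) on this single piece of evidence. For compound 3 the estimated value is 28000 nM with an expected range from 9000 nM to 85000 nM overall.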

Compound 3, half-maximal inhibitory concentration: > 100000 nM
Compound 3 ended at the assay's limit; the forecaster's own chance of this, stated with the estimate: 10%; at least 3.5-fold (0.55 log units) between middle value and limit.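

Compound 3 sits at a limit of the assay, not at a measured number: the limit of > 100000 nM in this assay, at which 1 of the 3 values shown sits.

Benzyl still carries a six-membered aromatic ring of carbon only, yet this change gives an at least 10-fold higher number from compound 2 to compound 3 (1.03 log units; beyond the scatter), so having such a ring on this amide-type nitrogen is not enough to keep the inhibition of compound 2. Benzyl in place of 2-methoxyphenyl gives an at least 1.4-fold higher number from compound 1 to compound 3 (0.14 log units; that floor lies within the scatter), and that floor sets no order between the two compounds.

Open, from the compounds shown here alone, is whether a 3-bromo-4-fluorobenzyl group on this nitrogen would restore the lower number. Also open, going by these compounds, is how an aryl ring carrying an amine or a carboxylic acid would fare here.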